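The source may report more compounds than this note shows. Statements on the series, on what has been measured and on what is new or still open speak of the compounds shown alone.

Series notes. Compound 1 `O=C(Oc1ccc(Cl)cc1C(=O)Nc1ccc(C(F)(F)F)cc1)c1cnc(Cl)cn1` and compound 2 `O=C(Oc1ccc(Br)cc1C(=O)Nc1ccc(C(F)(F)F)cc1)c1cnc(Cl)cn1` share one core; compound 3 `O=C(NCCCCl)Oc1ccc(Cl)cc1C(=O)Nc1ccc(C(=O)c2ccccc2)cc1` and compound 4 `O=C(NCCCCl)Oc1ccc(Br)cc1C(=O)Nc1ccc(C(=O)c2ccccc2)cc1` share another, and the difference between the two cores is not broken down here. In a physicochemical assay for solubility, read by spectrophotometry (on this read-out higher numbers stand for higher solubility and lower numbers for lower solubility), compound 1 gives only a limit, < 100000 nM. Compound 2 likewise sits at a limit, < 100000 nM. Compound 3 also sits at a limit, < 50000 nM. The change bromo in place of chloro on an aromatic carbon gives a step that the two limits leave unreadable from compound 1 to compound 2, which cannot be sized since both values rest at the limit of < 100000 nM in this assay, at which 2 of the 3 values shown sit. The change bromo in place of chloro on an aromatic carbon is the same kind of change, but here the carbon is para to a ((3-chloropropyl)carbamoyl)oxy group rather than para to a ((5-chloropyrazin-2-yl)carbonyl)oxy group. With compound 3 resting at the limit of < 50000 nM in this assay, at which 1 of the 3 values shown sits, the step expected is a step that the limit leaves unreadable from compound 3 to compound 4. Compound 4 is estimated at 20000 nM, between 2000 nM and 50000 nM, most likely again reported as a limit.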

Compound 4, solubility: < 50000 nM
Compound 4: only a limit was reported (the forecaster's own chance of this, stated with the estimate: 70%); the middle value lies beyond the limit too.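

In this assay compound 4 gives < 50000 nM, a limit, as compound 3 does, so no step can be read between compound 3 and compound 4: the limit of < 50000 nM in this assay, at which 2 of the 4 values shown sit.

The compounds shown leave open whether bromo in place of chloro shifts the read-out in this assay at all, on either core.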